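A few compounds are considered here, and "the series" means these few. Any claim that something is new, unique, unknown or untested is made for them only; others in the source may bear on it.

The measured compounds are these: compound 1, `CCCC(Nc1cncc(-c2ccc(NC(C)=O)c(OC)c2)n1)c1cccnc1`, which in a functional assay on PC-3 cells (Homo sapiens) for cytotoxicity, read by MTT assay, with a stated time of 72 h (a lower number here means a stronger inhibitor, a higher number a weaker inhibitor), gives 5000 nM; and compound 2, `CCCC(Nc1cncc(-c2ccc(NC(=O)NCC)c(OC)c2)n1)c1cccnc1`, which in this assay gives 40 nM.

Compound 2 holds the lower of the two numbers. Going by the values given here, its only neighbour is compound 1, and the two are separated by a 130-fold lower number from compound 1 to compound 2 (2.10 log units; beyond the scatter), a large step that came from the exchange at the carbonyl carbon, where an acetamide became an ethylurea.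

Compound 3, `CCCC(Nc1cncc(-c2ccc(NC(=O)NCCN(C)C)c(OC)c2)n1)c1cccnc1`, has not yet been measured in this assay. It differs from compound 2 by dimethylamino in place of hydrogen on a saturated chain carbon, two bonds along the chain from an amide-type nitrogen. The ethylurea that set compound 2 apart from compound 1 is kept intact; the change only lengthens the substituent on the urea nitrogen. Among the compounds with values here, the one measured step, a 130-fold lower number from compound 1 to compound 2 (2.10 log units; beyond the scatter), concerns a different part of the molecule and gives no direct guide to this kind of chain extension. Within the data shown here, with no step of this type on record, the change is expected to be small, amounting to no change at the digits printed from compound 2 to compound 3 (within the scatter), inside the usual scatter. Compound 3 is therefore estimated at 40 nM, within a range from 12 nM to 130 nM.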

Compound 3, half-maximal inhibitory concentration: 1000 nM
For compound 3 the middle estimate is 25-fold (1.40 log units) below the measured one; measured number outside the range, above it.
By their numbers in this assay, from the lowest: compound 2; then compound 3; then compound 1.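

The end of the urea substituent proves sensitive in this assay: dimethylamino in place of hydrogen on a saturated chain carbon, two bonds along the chain from an amide-type nitrogen, gives a 25-fold higher number from compound 2 to compound 3 (1.40 log units; beyond the scatter), a large step. The urea is therefore not enough by itself to hold the low number of compound 2, and what it carries counts as well. With (2-(dimethylamino)ethyl)amino in place of methyl on the carbonyl carbon, the step is a 5.0-fold lower number from compound 1 to compound 3 (0.70 log units; beyond the scatter), which is modest beside the large 130-fold lower number from compound 1 to compound 2 (2.10 log units; beyond the scatter) obtained with ethylamino at that same carbon; nothing on hand explains this difference between the two substituents.

The compounds shown leave open whether the higher number of compound 3 goes with the dimethylamino group itself or with the longer substituent, a question that a plain propyl or butyl chain on the urea nitrogen would address. They also leave open how a hydroxyl group, a methoxy group or a morpholine ring in place of dimethylamino at that chain carbon would read in this assay.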